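Ester variation on the aminothiophene series

A few compounds are considered here, and "the series" means these few. Any claim that something is new, unique, unknown or untested is made for them only; others in the source may bear on it.

The shared core carries a dimethoxyphenyl group and an ester, and is read in an assay on isolated protein for inhibition of protein kinase C zeta type (Homo sapiens), with stated times of 1 h and 2.5 min, tested at 30 uM; on this read-out lower numbers stand for less inhibition and higher numbers for more inhibition at the one concentration tested (going by the name of the read-out). Compound 1 `CCOC(=O)c1cscc1-c1ccc(OC)c(OC)c1`, with hydrogen at the ring position, gives 3%. Among the compounds with values here, compound 2 `CCOC(=O)c1c(-c2ccc(OC)c(OC)c2)csc1NC`, with methylamino at that position, gives 32%, and the step of a number 29 percentage points higher from compound 1 to compound 2 (beyond the scatter) is the only measured one-place step in the set. Compound 3 `COc1ccc(-c2csc(N)c2C(=O)Oc2ccccc2)cc1OC`, an amino compound with a phenyl ester, gives 48% and stands highest of the three numbers, beyond the scatter above both compound 2 and compound 1.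

Compound 4 `COc1ccc(-c2csc(N)c2C(=O)OCc2ccccc2F)cc1OC` differs from compound 3 only at the ester oxygen: 2-fluorobenzyl in place of phenyl on an oxygen next to a carbonyl group. Within the data shown here, no measured step touches the group on the ester oxygen; the one step on record, from compound 1 to compound 2, concerns the ring substituent, so it does not bear on this change. With no guidance either way, the expected step of a number 3 percentage points lower from compound 3 to compound 4 (within the scatter) in this assay is none beyond the scatter. Compound 4 is therefore estimated at 45%, with a range from 25% to 65%.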

Compound 4, a percentage reported as inhibition, at one concentration (the size of the read-out at that concentration, not a potency): 100%
The estimate for compound 4 lay 55 percentage points below the measured number; measured number above the stated range.
By their numbers in this assay, from the lowest: compound 1; then compound 2; then compound 3; then compound 4.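

The group on an oxygen next to a carbonyl group turns out to be a strong lever in this assay: 2-fluorobenzyl in place of phenyl gives a number 52 percentage points higher from compound 3 to compound 4 (beyond the scatter), with the amino group and the rest of the shared core unchanged. Within the data shown here, the earlier compounds showed movement only with the ring substituent, so this is the first sign that the ester group alone can shift this read-out by a large margin. No evidence in hand accounts for the step.

The one change swaps an aromatic ring on the oxygen for a benzyl group that also carries fluorine, so the compounds shown do not separate the two. A plain benzyl ester would divide the step between them, while a carboxylic acid or an amide would test whether the ester linkage itself matters.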